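Three Compounds at the Limit and a Fourth Expected There

This account rests on a few compounds, and the source may have more. Where it says the series, first, only, none or still open, it means among the compounds named here.

Measured compounds: compound 1 `CS/C(=N\C(=O)c1ccno1)NC(=O)c1ccno1` with > 100000 nM; compound 2 `O=C(/N=C(/NC(=O)c1ccno1)[Se]Cc1ccccc1)c1ccno1` with > 100000 nM; compound 3 `O=C(/N=C(/NC(=O)c1cccs1)[Se]Cc1ccccc1)c1cccs1` with > 100000 nM.

In a functional assay on PC-3 cells (Homo sapiens) for cytotoxicity, read by MTT assay, with a stated time of 72 h (on this read-out higher numbers stand for weaker inhibition of growth and lower numbers for stronger inhibition of growth), compound 1 gives > 100000 nM, which is a limit of the assay and not a number. Compound 2 likewise reaches only a limit, > 100000 nM, in this assay. Compound 3 also gives a limit, > 100000 nM, in this assay. The step from compound 2 to compound 1 is a step that the two limits leave unreadable from compound 2 to compound 1, the change being (a group of 2 heavy atoms (1 carbon, 1 sulfur; no ring) in place of a group of 8 heavy atoms (7 carbon, 1 selenium; one six-membered aromatic ring of carbon only), on a carbon with a double bond to nitrogen). The difference between the core of compound 2 and the core of compound 3 is not broken down here.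

Compound 4 `CS/C(=N\C(=O)c1cccs1)NC(=O)c1cccs1` has not yet been measured in this assay. It differs from compound 3 by a group of 2 heavy atoms (1 carbon, 1 sulfur; no ring) in place of a group of 8 heavy atoms (7 carbon, 1 selenium; one six-membered aromatic ring of carbon only), on a carbon with a double bond to nitrogen, the same change as that from compound 2 to compound 1, since the two surroundings of the change are described in the same words. Because (the limit of > 100000 nM in this assay, at which 3 of the 3 values shown sit), compound 4 is expected to sit at the same limit, with an expected step of a number no higher from compound 3 to compound 4 (the limit leaves the size open). The estimate for compound 4 in this assay is 100000 nM, between 30000 nM and 300000 nM.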

Compound 4, concentration for total growth inhibition: 98300 nM
Estimate against measurement, compound 4: 1.0-fold (0.01 log units) above; the measured number falls inside the stated range.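

On the core of compound 3, putting methylsulfanyl in place of the selenium-containing group gives an at least 1.0-fold lower number from compound 3 to compound 4 (0.00 log units; that floor lies within the scatter), so the change is not shown to lower the number at all. In this assay compound 4 gives 98300 nM, a true number rather than a limit. The same change on the other core, from compound 2 to compound 1, cannot be read, since both of its values are limits, so the series does not show that the change has the same size on both cores, or that it differs between them. The comparison across cores rests on very little: the limit of > 100000 nM in this assay, at which 3 of the 4 values shown sit.

The compounds shown leave open whether an amine or a longer alkyl chain in place of methylsulfanyl, on the carbon with a double bond to nitrogen, would give a number clearly away from the limit. They also leave open how far the values of compound 1 and compound 2 lie past that limit.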